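The compounds below may be only part of what the source reports. "The series", "measured", "known", "first", "only" and "open" are said of these compounds alone.

In an ADME assay on L02 cells (Homo sapiens) for antiproliferative activity, read by MTT assay, with a stated time of 48 h (on this read-out higher numbers stand for weaker inhibition and lower numbers for stronger inhibition), compound 1 `CCn1c(C(=O)NCCN(C)C)ccc1C(CC)(CC)c1ccc(OCCC(O)(CC)CC)c(C)c1` gives 990 nM and compound 2 `CCN(CC)CCNC(=O)c1ccc(C(CC)(CC)c2ccc(OCCC(O)(CC)CC)c(C)c2)n1CC` gives 2290 nM as the higher of the two numbers. Compound 3 `CCn1c(C(=O)NCC#N)ccc1C(CC)(CC)c1ccc(OCCC(O)(CC)CC)c(C)c1` differs from compound 2 by cyano in place of (diethylamino)methyl on a saturated chain carbon bound to an amide-type nitrogen. Going by the values given here, only one measured step touches this chain, a 2.3-fold higher number from compound 1 to compound 2 (0.36 log units; beyond the scatter) (modest), and it alters the amine end alone, so it is weak guidance. A step of similar size towards a higher number is expected in this assay here. Compound 3 is estimated at 5000 nM within 1800 nM to 14000 nM as its expected range. This estimate means an expected 2.2-fold higher number from compound 2 to compound 3 (0.34 log units; beyond the scatter) in these notes.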

Compound 3, half-maximal inhibitory concentration: > 50000 nM
Compound 3: no number, only a limit; the forecaster's own chance of this, stated with the estimate: 10%; middle value at least 10-fold (1.00 log units) away from the limit.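

In this assay the entry for compound 3 is a limit and not a number: the limit of > 50000 nM in this assay, at which 1 of the 3 values shown sits. The chain end at this position carries far more weight than the amine swap suggested: the earlier change gave only a 2.3-fold higher number from compound 1 to compound 2 (0.36 log units; beyond the scatter), whereas cyano in place of the aminomethyl end gives an at least 21-fold higher number from compound 2 to compound 3 (1.33 log units; beyond the scatter) and an at least 50-fold higher number from compound 1 to compound 3 (1.70 log units; beyond the scatter). With only these compounds, the shift cannot be assigned to losing the amine or to gaining the nitrile. A morpholine or a primary amine on the same chain, or a longer chain ending in nitrile, would separate the two.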